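Acetyl for hydrogen on a nitrogen, tested a second time

The source may report more compounds than this note shows. Statements on the series, on what has been measured and on what is new or still open speak of the compounds shown alone.

Measured so far in a functional assay on DU-145 cells (Homo sapiens) for cytotoxicity, read by XTT assay, with a stated time of 72 h; on this read-out lower numbers stand for stronger inhibition and higher numbers for weaker inhibition:
compound 1, `COc1ccc(/C=N/Nc2nc(C)c[se]2)cc1`, gives > 84900 nM, which is a limit of the assay.
compound 2, `CC(=O)c1[se]c(N/N=C/c2csc(-c3ccccc3)n2)nc1C`, gives 49900 nM.
compound 3, `COc1ccc(/C=N/N(C(C)=O)c2nc(C)c[se]2)cc1`, gives > 74300 nM, which is a limit of the assay.

Compound 3 differs from compound 1 by acetyl in place of hydrogen on a nitrogen on an aromatic ring. Since compound 1 sits at the limit of > 84900 nM in this assay, at which 1 of the 3 values shown sits, and compound 3 sits at the limit of > 74300 nM in this assay, at which 1 of the 3 values shown sits, the step that the two limits leave unreadable from compound 1 to compound 3 cannot be sized, and the earlier pair gives no read on the change. Compound 2 carries a different core from compound 1; the difference between the two cores is not broken down here. Compound 2 is the only one of the three with a number rather than a limit in this assay.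

Compound 4, `CC(=O)c1[se]c(N(/N=C/c2csc(-c3ccccc3)n2)C(C)=O)nc1C`, differs from compound 2 by acetyl in place of hydrogen on a nitrogen on an aromatic ring, the same change as that from compound 1 to compound 3, at a place described in identical words. With the earlier step unreadable, the expectation for compound 4 rests only on compound 2 giving 49900 nM, and the step of a 1.2-fold higher number from compound 2 to compound 4 (0.08 log units; within the scatter) is estimated to stay small. Compound 4 is therefore expected to come in near 60000 nM, most likely between 25000 nM and 150000 nM, with a fair chance that this assay reports only a limit for it.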

Compound 4, half-maximal inhibitory concentration: 31300 nM
Estimate against measurement, compound 4: 1.9-fold (0.28 log units) above; measured number inside the range.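

In this assay, acetyl in place of hydrogen on a nitrogen on an aromatic ring gives a 1.6-fold lower number from compound 2 to compound 4 (0.20 log units; within the scatter), so on the core of compound 2 the change leaves the two compounds indistinguishable. Among the compounds shown here, this does not show that the change behaves alike on both cores, since the only other example involves compound 3, which stands at a limit of the assay and not at a number: the limit of > 74300 nM in this assay, at which 1 of the 4 values shown sits. Compound 1 also stands at a limit, so the step on its core cannot be read and any statement about carrying the change across cores rests on one readable pair alone: the limit of > 84900 nM in this assay, at which 1 of the 4 values shown sits.

The compounds shown leave open what a group other than acetyl, such as a longer chain or an amine, would do on that nitrogen in this assay. They also leave open how the acetyl change would read on a further core where both partners give a number rather than a limit.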